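Ester to amide on the fused core: Vero cytotoxicity

The source may report more compounds than this note shows. Statements on the series, on what has been measured and on what is new or still open speak of the compounds shown alone.

Compound 1 `O=C(NCc1ccccc1)c1coc(-c2ccccc2)n1` belongs to the same set but stands apart in its core; in an ADME assay on Vero cells (Chlorocebus sabaeus) for cytotoxicity, with a stated time of 72 h (a lower number here means a stronger inhibitor, a higher number a weaker inhibitor), compound 1 gives "not determined" (no result reported), so it contributes no number here. Compound 2 `Cc1ccn2c(C(=O)OCc3ccccc3)c(-c3ccccc3)nc2c1` carries a benzyl ester on its fused core. In this assay compound 2 gives > 50000 nM, which is a limit of the assay and not a measured number. The position of compound 2 is therefore fixed only by the limit of > 50000 nM in this assay, at which 1 of the 2 values shown sits, and nothing sharper can be said about it.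

Compound 3 `Cc1ccn2c(C(=O)NCc3ccccc3)c(-c3ccccc3)nc2c1` differs from compound 2 in one place: benzylamino in place of benzyloxy on a carbonyl carbon. Within the data shown here, no step between two measured compounds exists in this set, so no measured guide is available. The expectation is that the change produces no shift beyond the usual scatter, an expected step that the limit leaves unreadable from compound 2 to compound 3. Compound 3 is accordingly expected to sit at about 60000 nM, within a range of 20000 nM to 200000 nM, and most probably to return again only a limit.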

Compound 3, half-maximal inhibitory concentration: > 50000 nM
Compound 3 was reported as a limit; the forecaster's own chance of this, stated with the estimate: 75%; the middle value is on the limit's open side.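

Compound 2 and compound 3 both stand only as limits in this assay, so no step between them can be read: the limit of > 50000 nM in this assay, at which 2 of the 3 values shown sit.

The compounds shown leave open whether benzylamino in place of benzyloxy on a carbonyl carbon changes the result in this assay at all.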